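Amide-nitrogen substituents in a phosphatase inhibitor series

A few compounds are considered here, and "the series" means these few. Any claim that something is new, unique, unknown or untested is made for them only; others in the source may bear on it.

Compound 1 `CCCNC(=O)COc1ccc2cc(C(O)(C(F)(F)F)C(F)(F)F)c(O)cc2c1` gives in an assay on isolated protein for inhibition of receptor-type tyrosine-protein phosphatase C (Homo sapiens), read by spectrophotometry (on this read-out higher numbers stand for weaker inhibition and lower numbers for stronger inhibition), only a limit: > 20000 nM.
Compound 2 `O=C(COc1ccc2cc(C(O)(C(F)(F)F)C(F)(F)F)c(O)cc2c1)Nc1ccc(-c2ccccc2)cc1` gives in this assay 3400 nM.
Compound 3 `COc1ccc(CNC(=O)COc2ccc3cc(C(O)(C(F)(F)F)C(F)(F)F)c(O)cc3c2)cc1OC` gives in this assay only a limit: > 20000 nM.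

Compound 3 sits at the limit of > 20000 nM in this assay, at which 2 of the 3 values shown sit, so its own value is not a number but a boundary. Compound 4 `CC(C)c1ccc(NC(=O)COc2ccc3cc(C(O)(C(F)(F)F)C(F)(F)F)c(O)cc3c2)cc1` differs from it by 4-isopropylphenyl in place of 3,4-dimethoxybenzyl on an amide-type nitrogen; the amide-type nitrogen carries an aryl group directly, as in compound 2, rather than a benzyl-type group. Going by the values given here, two measured steps bear on this. The step of an at least 5.8-fold lower number from compound 1 to compound 2 (0.76 log units; beyond the scatter) shows that an aryl group on the amide-type nitrogen can bring the number down from the limit to a readable value. The step of an at least 5.8-fold higher number from compound 2 to compound 3 (0.76 log units; beyond the scatter) shows the reverse direction on going from aryl to benzyl-type. The change a step that the two limits leave unreadable from compound 1 to compound 3 is not readable. Since 4-isopropylphenyl is smaller than 4-phenylphenyl, a number between compound 2 and the limit is expected; the estimated step is an at least 2.5-fold lower number from compound 3 to compound 4 (0.39 log units; beyond the scatter). Compound 4 is thus expected to give 8000 nM, within 3000 nM to 20000 nM.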

Compound 4, half-maximal inhibitory concentration: 7800 nM
Compound 4: middle estimate off by 1.0-fold (0.01 log units), on the high side; measured number inside the range.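

With 4-isopropylphenyl on the amide-type nitrogen, this assay shows an at least 2.5-fold lower number from compound 1 to compound 4 (0.40 log units; beyond the scatter) and an at least 2.5-fold lower number from compound 3 to compound 4 (0.40 log units; beyond the scatter), so a readable value does not depend on 4-phenylphenyl alone. Both of these steps start from a limit rather than a number: the limit of > 20000 nM in this assay, at which 2 of the 4 values shown sit. Isopropyl in place of phenyl on the aromatic carbon gives a 2.3-fold higher number from compound 2 to compound 4 (0.36 log units; beyond the scatter), the only step shown between two readable numbers, so the group on that carbon still changes the value.

From the compounds shown here alone, compound 3 and compound 4 differ in the attachment to the amide-type nitrogen and in the ring substituents together, so the contribution of each stays open. Also open, going by these compounds, is how a carboxylic acid or an amine would read in place of isopropyl on the aromatic carbon.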